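A tert-butyl for a methyl on a carbonyl carbon

A few compounds are considered here, and "the series" means these few. Any claim that something is new, unique, unknown or untested is made for them only; others in the source may bear on it.

Compound 1 `CC(C)(C)C(=O)OCC1(CO)C/C(=C\CCCCCCCCCCCO)C(=O)O1`: > 10 ug/mL, a limit
Compound 2 `CC(C)(C)C(=O)OCC1(CO)C/C(=C\CCCCCCCCCCCCCCC=O)C(=O)O1`: > 10 ug/mL, a limit
Compound 3 `CC(=O)OCCCCCCCCCCCCCCC/C=C1\CC(CO)(COC(=O)C(C)(C)C)OC1=O`: > 10 ug/mL, a limit

In a functional assay on NCI-H322 cells (Homo sapiens) for antiproliferative activity (a lower number here means a stronger inhibitor of growth, a higher number a weaker inhibitor of growth), compound 3 gives no number, only the limit > 10 ug/mL. It shares that reading with both of the other measured compounds: the limit of > 10 ug/mL in this assay, at which 3 of the 3 values shown sit. Compound 4 `CC(C)(C)C(=O)OCCCCCCCCCCCCCCC/C=C1\CC(CO)(COC(=O)C(C)(C)C)OC1=O` differs from compound 3 in one place: tert-butyl in place of methyl on a carbonyl carbon. This is tert-butyl in place of methyl on a carbonyl carbon, so that acetoxy becomes ((tert-butyl)carbonyl)oxy.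

For the measured compounds named here, two measured steps bear most directly on this change, since both lead to the acetoxy group of compound 3: a step that the two limits leave unreadable from compound 1 to compound 3 and a step that the two limits leave unreadable from compound 2 to compound 3. The third step, a step that the two limits leave unreadable from compound 1 to compound 2, adds no more. None of the three has a size that can be carried over, and none shows a direction. Going by the values given here, no step of the tert-butyl change itself has been measured. The expectation therefore rests on the series as a whole, where every change so far has left the reading at the limit in this assay.

The expected step is a step that the limit leaves unreadable from compound 3 to compound 4, and no firm direction is expected for it. Compound 4 is estimated at about 14 ug/mL, with an expected range of 7 ug/mL to 30 ug/mL, and it may well be reported only as a limit.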

Compound 4, concentration for 50% growth inhibition: > 10 ug/mL
Compound 4 ended at the assay's limit; the forecaster's own chance of this, stated with the estimate: 80%; the middle value does not contradict the limit.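

Compound 4 gives only a limit in this assay, as do compound 1, compound 2 and compound 3, so no step among these four compounds can be read: the limit of > 10 ug/mL in this assay, at which 4 of the 4 values shown sit.

The compounds shown leave open how strongly any of the four inhibits growth, and whether hydroxy, formyl, acetoxy and ((tert-butyl)carbonyl)oxy on the chain differ at all.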